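Methyl on the ring nitrogen of compound 1

This account rests on a few compounds, and the source may have more. Where it says the series, first, only, none or still open, it means among the compounds named here.

Measured compounds:
compound 1, `Cc1cc2[nH]nc(N)c2c(=O)[nH]1`, 56%
compound 2, `CC(C)(C)c1cc2[nH]nc(N)c2c(=O)[nH]1`, 65%
compound 3, `Nc1n[nH]c2cc(CC3CCNCC3)[nH]c(=O)c12`, 62%

In an assay on isolated protein for inhibition of ribosomal protein S6 kinase alpha-5 (Homo sapiens), read by mobility shift assay, tested at 30 uM (a lower number here means less inhibition, a higher number more inhibition at the concentration tested (going by the name of the read-out)), compound 1 gives 56%, the lowest of the three numbers, yet its nearest neighbour compound 3 stands only a number 6 percentage points higher from compound 1 to compound 3 (within the scatter) and compound 2 stands a number 9 percentage points higher from compound 1 to compound 2 (within the scatter), so the three measured compounds cannot be separated on this read-out.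

Compound 4, `Cc1cc2c(c(N)nn2C)c(=O)[nH]1`, differs from compound 1 by methyl in place of hydrogen on an aromatic nitrogen.

Neither measured step touches this position: the step from compound 1 to compound 2 replaces the methyl on an aromatic carbon, and the step from compound 1 to compound 3 adds a piperidin-4-yl on the saturated chain carbon. Going by the values given here, both were within the scatter, which says only that the number in this assay stays level across changes at those two places. For a methyl on the ring nitrogen no comparison exists, so the expectation rests on the measured spread alone and carries a wide range. The step from compound 1 to compound 4 is expected to be a number 11 percentage points lower from compound 1 to compound 4 (beyond the scatter). For compound 4 the estimate is 45%, between 15% and 70%.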

Compound 4, a percentage reported as inhibition, at one concentration (the size of the read-out at that concentration, not a potency): 4%
The estimate for compound 4 lay 41 percentage points above the measured number, and the stated range ends above it.
By their numbers in this assay, from the lowest: compound 4; then compounds 1, 3 and 2 (each within the scatter of the next).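

In this assay, going by these compounds alone, methyl in place of hydrogen on the aromatic nitrogen gives a number 52 percentage points lower from compound 1 to compound 4 (beyond the scatter), the only step so far that lies beyond the scatter. The number stayed level across the changes at the other two places, so this position of the five-membered aromatic ring, next to the ring nitrogen, is the first shown to respond strongly, and to a substituent of only one carbon. No measurement at hand bears on the cause of this step.

Going by these compounds, whether any group on this nitrogen gives the same drop or only methyl does stays open; an ethyl group, a longer chain or a hydroxyethyl group there would help separate the two. Also open, on these data alone, is whether the methyl has a step of similar size when combined with the tert-butyl of compound 2 or the piperidin-4-yl of compound 3.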